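Heteroaryl amines on the shared core: expectation for compound 4

This account rests on a few compounds, and the source may have more. Where it says the series, first, only, none or still open, it means among the compounds named here.

Compound 1 `C[C@@H](Cn1ccc(-c2ccc(C#N)c(Cl)c2)n1)NC(=O)c1ccccc1` carries a benzoyl group on the amine nitrogen of the shared core, and in a functional assay on LNCaP cells (Homo sapiens) for antiproliferative activity, read by CCK-8 assay, with a stated time of 6 days (a lower number here means a stronger inhibitor, a higher number a weaker inhibitor), compound 1 gives 1830 nM. Compound 2 `C[C@@H](Cn1ccc(-c2ccc(C#N)c(Cl)c2)n1)NS(=O)(=O)c1cn(C)cn1` carries a (1-methyl-1H-imidazol-4-yl)sulfonyl group there; in this assay compound 2 reaches > 30000 nM, which is a limit of the assay and not a number. Compound 3 `C[C@@H](Cn1ccc(-c2ccc(C#N)c(Cl)c2)n1)Nc1ccncc1` carries pyridin-4-yl on the same nitrogen, and in this assay compound 3 gives 2560 nM. Of the two numbers compound 3 holds the higher one, but the gap to compound 1 is small: a 1.4-fold higher number from compound 1 to compound 3 (0.15 log units; within the scatter). The sulfonyl exchange is of another size: an at least 16-fold higher number from compound 1 to compound 2 (1.21 log units; beyond the scatter) and an at least 11-fold lower number from compound 2 to compound 3 (1.06 log units; beyond the scatter), with compound 2 sitting at the limit of > 30000 nM in this assay, at which 1 of the 3 values shown sits.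

Compound 4 `C[C@@H](Cn1ccc(-c2ccc(C#N)c(Cl)c2)n1)Nc1ncccn1` differs from compound 3 in one place: pyrimidin-2-yl in place of pyridin-4-yl on an amine nitrogen. Among the compounds with values here, no measured step exchanges one six-membered aromatic ring for another on this nitrogen; the only aromatic-ring amine measured, compound 3, stands close to compound 1 in this assay. Compound 4 is expected to show a step of a 1.2-fold higher number from compound 3 to compound 4 (0.07 log units; within the scatter), none beyond the scatter. Compound 4 is estimated at 3000 nM, with a range from 1200 nM to 8000 nM.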

Compound 4, half-maximal inhibitory concentration: 1180 nM
Estimate against measurement, compound 4: 2.5-fold (0.41 log units) above, and the stated range ends above it.
By their numbers in this assay, from the lowest: compounds 4, 1 and 3 (each within the scatter of the next, the first and the last beyond it). At a limit, above all of these: compound 2.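

In this assay, exchanging one six-membered aromatic ring for another on the amine nitrogen gives a step of its own, a 2.2-fold lower number from compound 3 to compound 4 (0.34 log units; beyond the scatter), so the two heteroaryl amines can be told apart, with the lower number on the ring holding 2 hetero atoms. Against the benzoyl group the exchange gives a 1.6-fold lower number from compound 1 to compound 4 (0.19 log units; within the scatter), which leaves compound 4 and compound 1 without an order. The sulfonyl exchange is read against a limit of the assay and not a number, with an at least 25-fold lower number from compound 2 to compound 4 (1.40 log units; beyond the scatter), and the bound is this: the limit of > 30000 nM in this assay, at which 1 of the 4 values shown sits.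

Open, going by these compounds, is whether the step from pyridin-4-yl to pyrimidin-2-yl follows the count of ring hetero atoms or their arrangement, on which a pyridin-2-yl group on the same nitrogen would bear. Also open, on these data alone, is how a saturated ring such as piperidin-4-yl would read there.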